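Adding tert-butyl to compound 1: working notes

The compounds below may be only part of what the source reports. "The series", "measured", "known", "first", "only" and "open" are said of these compounds alone.

Measured in a physicochemical assay for solubility, in phosphate buffer, at pH 7.4 (a lower number here means a less soluble compound, a higher number a more soluble compound), so far:
compound 1 `CCOC(=O)c1c(-c2ccccc2)[nH]c2cc(OC)ccc2c1=O` gives > 100000 nM (a limit)
compound 2 `CCOC(=O)c1c(-c2cccc(C)c2)[nH]c2cc(OC)ccc2c1=O` gives 48000 nM
compound 3 `CCOC(=O)c1c(-c2ccccc2Cl)[nH]c2cc(OC)ccc2c1=O` gives 28000 nM

Compound 1 stands at > 100000 nM in this assay as a limit and not a number. Compound 4 `CCOC(=O)c1c(-c2ccc(C(C)(C)C)cc2)[nH]c2cc(OC)ccc2c1=O` carries tert-butyl in place of hydrogen on an aromatic carbon, para to a large group (tert-butyl in place of hydrogen on an aromatic carbon). Among the measured compounds shown here, two measured steps bear on this change, and both lie beyond the scatter: methyl in place of hydrogen (an at least 2.0-fold lower number from compound 1 to compound 2 (0.31 log units; beyond the scatter)) and chloro in place of hydrogen (an at least 3.5-fold lower number from compound 1 to compound 3 (0.55 log units; beyond the scatter)). The remaining step (a 1.7-fold lower number from compound 2 to compound 3 (0.23 log units; within the scatter)) stays within the scatter. On those two steps, a lower number is expected in this assay with an estimated size of an at least 6.6-fold lower number from compound 1 to compound 4 (0.82 log units; beyond the scatter) overall. For compound 4 the estimate is 15000 nM with an expected range from 4000 nM to 45000 nM as a working figure.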

Compound 4, solubility: 2000 nM
Estimate against measurement, compound 4: 7.5-fold (0.88 log units) above; the whole stated range lies above it.
By their numbers in this assay, from the lowest: compound 4; then compounds 3 and 2 (each within the scatter of the next). At a limit, above all of these: compound 1.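

In this assay, among the compounds shown here, tert-butyl on an aromatic carbon, para to a large group, gives an at least 50-fold lower number from compound 1 to compound 4 (1.69 log units; beyond the scatter), the only step graded large; the methyl and chloro steps reached no such size. The step is a lower bound, since the entry for compound 1 is a limit and not a number: the limit of > 100000 nM in this assay, at which 1 of the 4 values shown sits.

From the compounds shown here alone, whether an amine or a carboxylic acid at this same place would give a higher number stays open. Also open, going by these compounds, is how methyl or chloro would read at this place, so the effect of the group remains unseparated from that of its position.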